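A few compounds are considered here, and "the series" means these few. Any claim that something is new, unique, unknown or untested is made for them only; others in the source may bear on it.

Measured so far:
- compound 1, `O=C(O)CCc1ccncc1-c1ccc2ccccc2c1`: 50.5 nM
- compound 2, `NNC(=O)CCc1ccncc1-c1ccc2ccccc2c1`: 7.7 nM
- compound 3, `COC(=O)CCc1ccncc1-c1ccc2ccccc2c1`: 259 nM

Series notes. All three share one core; they differ only in the group at the end of the chain on the carbonyl carbon. In an assay on a protein complex for inhibition of CDK8/Cyclin C (Homo sapiens), with a stated time of 1 h (a lower number here means a stronger inhibitor, a higher number a weaker inhibitor), compound 3 gives 259 nM, the highest number of the three and so the weakest inhibitor here: compound 1 gives 50.5 nM and compound 2 gives 7.7 nM. The steps are a 5.1-fold higher number from compound 1 to compound 3 (0.71 log units; beyond the scatter) and a 34-fold higher number from compound 2 to compound 3 (1.53 log units; beyond the scatter); the step of a 6.6-fold lower number from compound 1 to compound 2 (0.82 log units; beyond the scatter) connects the other two.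

Compound 4, `CN(C)C(=O)/C=C/c1ccncc1-c1ccc2ccccc2c1`, is not yet measured. It differs from compound 3 as follows: 2-(dimethylcarbamoyl)ethenyl in place of 2-(methoxycarbonyl)ethyl on an aromatic carbon.

Within the data shown here, two measured steps bear on the change. Both replacements at the carbonyl carbon moved this assay by a modest to large amount, and the methyl ester of compound 3 is the weakest of the three. Exchanging the ester for a carbonyl bearing a dimethylamino nitrogen, with the chain now unsaturated, is a change of the same kind; the combined exchange is without precedent in the set, so the expectation is loose. A step back toward compound 1 is expected rather than a further rise, but the unsaturated chain adds uncertainty in either direction.

For compound 4 the expected value in this assay is 60 nM, with a range of 15 nM to 250 nM, which corresponds to an expected step of a 4.3-fold lower number from compound 3 to compound 4 (0.64 log units; beyond the scatter).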

Compound 4, half-maximal inhibitory concentration: 30.1 nM
Beside the measured number, compound 4's estimate is 2.0-fold (0.30 log units) above it; measured number inside the range.
By their numbers in this assay, from the lowest: compound 2; then compounds 4 and 1 (each within the scatter of the next); then compound 3.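

In this assay, the 2-(dimethylcarbamoyl)ethenyl group on this aromatic carbon, opposite the ring nitrogen, gives an 8.6-fold lower number from compound 3 to compound 4 (0.93 log units; beyond the scatter); neither this group nor the 2-(methoxycarbonyl)ethyl group it replaces counts a hydrogen-bond donor, so the number at this position can shift substantially with no donor entering, and the change also shows that an unsaturated chain is compatible with a number far from that of compound 3. The hydrazide end group of compound 2 still stands apart, with a 3.9-fold higher number from compound 2 to compound 4 (0.59 log units; beyond the scatter), while a 1.7-fold lower number from compound 1 to compound 4 (0.22 log units; within the scatter) leaves compound 1 and compound 4 unseparated even though their side chains differ in both end group and chain saturation. No measurement shown here explains any of these steps.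

As far as these compounds go, the double bond and the dimethylamino group on the carbonyl change together in compound 4, so their separate contributions remain unknown: the saturated 2-(dimethylcarbamoyl)ethyl chain and the unsaturated 2-(methoxycarbonyl)ethenyl chain would each isolate one of them. Also open, from the compounds shown here alone, is how a primary amide, a monomethyl amide or a longer chain would read at this position.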